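The source may report more compounds than this note shows. Statements on the series, on what has been measured and on what is new or still open speak of the compounds shown alone.

In a functional assay on cells (Panel NCI-60 (60 carcinoma cell lines), Homo sapiens) for inhibition, read by colorimetric assay, with a stated time of 3 days (a lower number here means a stronger inhibitor of growth, a higher number a weaker inhibitor of growth), compound 1 (`O=C(CCCCCCNC(=O)C(O)(O)C(F)(F)F)Nc1ccc(Br)cc1`) gives 20900 nM, and compound 2 (`O=C(CCCCCCNC(=O)C(O)(O)C(F)(F)F)Nc1ccc(-c2ccccc2)cc1`) gives 15100 nM. For the measured compounds named here, compound 2 therefore stands within the scatter of compound 1, the only other compound measured so far. Compound 3 (`O=C(CCCCCCNC(=O)C(O)(O)C(F)(F)F)Nc1ccc(Cl)cc1`) departs from compound 2 by a single change: chloro in place of phenyl on an aromatic carbon. Going by the values given here, the one measured step at this place, a 1.4-fold lower number from compound 1 to compound 2 (0.14 log units; within the scatter), put phenyl in place of bromo and stayed within the scatter. Among the compounds with values here, compound 3 reverses that kind of exchange, with chloro rather than bromo as the halogen, and no measurement yet shows what chloro does here. No step beyond the scatter is therefore expected in this assay. The expected step is a 1.3-fold higher number from compound 2 to compound 3 (0.12 log units; within the scatter), which would leave compound 3 close to the bromo compound 1 at 20900 nM. Compound 3 is estimated at 20000 nM, with an expected range of 11000 nM to 36000 nM.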

Compound 3, concentration for total growth inhibition: 26900 nM
The estimate for compound 3 lay 1.3-fold (0.13 log units) below the measured number; the range from low to high includes it.
By their numbers in this assay, from the lowest: compounds 2, 1 and 3 (each within the scatter of the next).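

Exchanging phenyl for chloro on this aromatic carbon (a 1.8-fold higher number from compound 2 to compound 3 (0.25 log units; within the scatter)) removes a whole six-membered aromatic ring of carbon only, yet the change stays within the scatter. The two halogens also cannot be told apart here (a 1.3-fold higher number from compound 1 to compound 3 (0.11 log units; within the scatter)). Chloro, bromo and phenyl at this place, para to a large group, therefore give numbers within the scatter of one another in this assay and so show no dependence on the group in this set, and nothing available bears on the reason for this.

Going by these compounds, it remains open whether an amine or a carboxylic acid at this same carbon would produce a step beyond the scatter. On these data alone, it is equally open whether a shorter or longer chain in the shared core would do so.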